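Swapping methylamino for 2-methylpiperidinyl on the sulfonyl sulfur

This account rests on a few compounds, and the source may have more. Where it says the series, first, only, none or still open, it means among the compounds named here.

Three compounds were measured in an assay on CHO cells for displacement of a labelled ligand from prostaglandin D2 receptor 2 (Homo sapiens), read by scintillation counting; a higher number here means a weaker inhibitor, a lower number a stronger inhibitor:
compound 1 `Cc1ccc(S(=O)(=O)Cc2ccccc2)cc1C#Cc1cc(Cl)ccc1OCC(=O)O`, 5 nM
compound 2 `Cc1ccc(S(=O)(=O)N(C)C(C)C)cc1C#Cc1cc(Cl)ccc1OCC(=O)O`, 3.8 nM
compound 3 `CNS(=O)(=O)c1ccc(C)c(C#Cc2cc(Cl)ccc2OCC(=O)O)c1`, 10 nM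

Compound 3 has the highest number of the three. Its gap to compound 1 is within the scatter (a 2.0-fold higher number from compound 1 to compound 3 (0.30 log units; within the scatter)), whereas the step from compound 2 to compound 3 is beyond it (a 2.6-fold higher number from compound 2 to compound 3 (0.42 log units; beyond the scatter)), a modest rise on replacing a substituent on the sulfonamide nitrogen with hydrogen. Compound 4 `Cc1ccc(S(=O)(=O)N2CCCCC2C)cc1C#Cc1cc(Cl)ccc1OCC(=O)O` differs from compound 3 in one place: 2-methylpiperidin-1-yl in place of methylamino on a sulfonyl sulfur. This returns to a nitrogen bearing two substituents, as in compound 2, so that step is the one that bears on it. Compound 4 is therefore expected to give a modestly lower number, a 2.2-fold lower number from compound 3 to compound 4 (0.35 log units; beyond the scatter). The estimate for compound 4 is 4.5 nM, ranging from 1.5 nM to 13 nM.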

Compound 4, inhibition constant: 1.9 nM
Compound 4: middle estimate off by 2.4-fold (0.37 log units), on the high side, and the stated range covers the measured number.
By their numbers in this assay, from the lowest: compounds 4, 2, 1 and 3 (each within the scatter of the next, the first and the last beyond it).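

Replacing methylamino, with its one hydrogen-bond donor, by the six-membered ring of 2-methylpiperidin-1-yl, with none, is tolerated on the sulfonyl sulfur and gives a clear gain (a 5.3-fold lower number from compound 3 to compound 4 (0.72 log units; beyond the scatter)). The ring cannot be told apart from open-chain isopropyl(methyl)amino (a 2.0-fold lower number from compound 2 to compound 4 (0.30 log units; within the scatter)), but it does separate from benzyl (a 2.6-fold lower number from compound 1 to compound 4 (0.42 log units; beyond the scatter)). No evidence shown here accounts for these steps. From the compounds shown here alone, whether plain piperidine, without the methyl group, or morpholine would hold this level on the sulfonyl sulfur remains open.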